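This account rests on a few compounds, and the source may have more. Where it says the series, first, only, none or still open, it means among the compounds named here.

Measured so far:
Compound 1, `Cc1ccc(Oc2c(/C=N\CCCCCOc3cc4oc(=O)cc(C)c4cc3Cl)c(C)nn2C)cc1`. In a functional assay on U-87MG ATCC cells for antiproliferative activity against U-87 MG (Homo sapiens), read by MTT assay, with a stated time of 72 h (a higher number here means a weaker inhibitor, a lower number a stronger inhibitor), compound 1 gives 7970 nM.
Compound 2, `Cc1nn(C)c(Oc2cccc(F)c2F)c1/C=N\CCCCCCOc1cc2oc(=O)cc(C)c2cc1Cl`. In this assay compound 2 gives only a limit of the assay, > 25000 nM.

Among the measured compounds shown here, compound 2 thus stands at the edge of what this assay can report: its reading is a limit, not a number, and it is the one value of the two that sits there, (the limit of > 25000 nM in this assay, at which 1 of the 2 values shown sits). Compound 1, by contrast, has a measured value and so counts as a weak but real inhibitor in this assay. For the measured compounds named here, no step between two measured compounds is at hand, since compound 1 and compound 2 differ in more than one place.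

Compound 3, `Cc1nn(C)c(Oc2cccc(Br)c2)c1/C=N\CCCCCCOc1cc2oc(=O)cc(C)c2cc1Cl`, keeps the core and the chain of compound 2 and changes only the group on an oxygen on an aromatic ring: 3-bromophenyl in place of 2,3-difluorophenyl on an oxygen on an aromatic ring. Going by the values given here, no measured pair shows what such a swap does here. The step expected from compound 2 to compound 3 in this assay is an at least 1.6-fold lower number from compound 2 to compound 3 (0.22 log units; that floor lies within the scatter), a modest move toward a measurable value rather than a large one, since compound 1 at 7970 nM is itself weak. Compound 3 is estimated at 15000 nM, with a range from 6000 nM to 30000 nM.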

Compound 3, half-maximal inhibitory concentration: 3610 nM
Compound 3: middle estimate off by 4.2-fold (0.62 log units), on the high side; measured number outside the range, below it.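

In this assay, with the core and chain held fixed, putting 3-bromophenyl in place of 2,3-difluorophenyl on the oxygen gives an at least 6.9-fold lower number from compound 2 to compound 3 (0.84 log units; beyond the scatter). Among the compounds shown here, this is the first sign that the group on this oxygen matters: the change alone is enough to bring a compound from the limit of the assay to a measured value, even though neither group carries a hydrogen-bond donor, a hydrogen-bond acceptor or a net charge. The true size of the step stays unknown and could be larger than the figure given, because compound 2 has only a limit and not a number: the limit of > 25000 nM in this assay, at which 1 of the 3 values shown sits.

Going by these compounds, the swap removes two fluorines and adds one bromine in a single move, so it remains open whether losing the fluorines or gaining the bromine drives the change, a question that a plain phenyl or a 3-chlorophenyl on the same oxygen could help settle. On these data alone, it is also open whether the same swap would have a similar effect on the different chain of compound 1, and whether a group of another kind, such as an amine or a carboxylic acid on the ring, would be tolerated here.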